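A few compounds are considered here, and "the series" means these few. Any claim that something is new, unique, unknown or untested is made for them only; others in the source may bear on it.

Measured in a functional assay on the whole organism with Rattus norvegicus as the target; a higher number here means that more compound is needed for the effect, a lower number that less compound is needed:
compound 1 `CC1CCC(=NNc2ccccc2)c2ncc(C(=O)O)c(=O)n21`: 1.2 umol/kg
compound 2 `Cc1cc(C)cc(NN=C2CCC(C)n3c2ncc(C(=O)O)c3=O)c1`: > 320 umol/kg

The value of compound 2 is a limit of the assay, not a number; it sits at the limit of > 320 umol/kg in this assay, at which 1 of the 2 values shown sits. Compound 1 carries the only number shown. For the measured compounds named here, the step of an at least 260-fold higher number from compound 1 to compound 2 (2.42 log units; beyond the scatter) is the one measured change at this position. Compound 3 `CC1CCC(=NNc2ccccn2)c2ncc(C(=O)O)c(=O)n21` differs from compound 1 by pyridin-2-yl in place of phenyl on an amine nitrogen. The measured step concerns a different group on the same nitrogen and so bears only loosely on this change; a step of a 2.1-fold higher number from compound 1 to compound 3 (0.32 log units; beyond the scatter) is expected, leaning toward a higher number, possibly none beyond the scatter. Compound 3 is estimated at 2.5 umol/kg, range 0.8 umol/kg to 15 umol/kg.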

Compound 3, dose for 50% inhibition: > 100 umol/kg
Compound 3 was reported as a limit; the forecaster's own chance of this, stated with the estimate: 15%; middle value at least 40-fold (1.60 log units) away from the limit.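

In this assay pyridin-2-yl in place of phenyl on the amine nitrogen gives an at least 83-fold higher number from compound 1 to compound 3 (1.92 log units; beyond the scatter) and so the large loss at this position is not confined to the 3,5-dimethylphenyl group, as a swap that keeps the heavy-atom count also produces one. The value of compound 3 is a limit of the assay, not a number: the limit of > 100 umol/kg in this assay, at which 1 of the 3 values shown sits. The step between compound 2 and compound 3 cannot be read, as both values are limits.

On these data alone, whether pyridin-3-yl, pyridin-4-yl or a phenyl carrying a single methyl or fluorine stays near compound 1 remains open.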